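Swapping a styryl arm for a direct biaryl link

A few compounds are considered here, and "the series" means these few. Any claim that something is new, unique, unknown or untested is made for them only; others in the source may bear on it.

Compound 1 `COC(=O)/C=C/c1cccc(N(Cc2ccc(/C=C/c3c(C)cc(C)cc3C)cc2)C(=O)C(C)C)c1` and compound 2 `COC(=O)/C=C/c1cccc(N(Cc2ccc(/C=C/c3cccc(Cl)c3)cc2)C(=O)C(C)C)c1` share one core and differ only at the far end of the double-bonded chain. In an assay on isolated protein with Bile acid receptor (Homo sapiens) as the target (a higher number here means that more compound is needed for the effect, a lower number that less compound is needed), compound 1 gives 149 nM, and compound 2 gives 164 nM, which is the higher of the two numbers, though the gap is within the scatter, as a 1.1-fold higher number from compound 1 to compound 2 (0.04 log units; within the scatter) shows. Compound 3 `COC(=O)/C=C/c1cccc(N(Cc2ccc(-c3cccc(OC)c3)cc2)C(=O)C(C)C)c1` takes a different route: 3-methoxyphenyl in place of 2-(3-chlorophenyl)ethenyl on an aromatic carbon. Here the ring that enters sits directly on the aromatic carbon, so the double-bonded chain itself disappears. Among the measured compounds shown here, no measured step covers this kind of change; the single step from compound 1 to compound 2 only varied the ring at the end of that chain and stayed within the scatter. Without guidance, a modest loss is the cautious expectation, so compound 3 is estimated at 450 nM, with a likely range from 120 nM to 2000 nM. That corresponds to an expected step of a 2.7-fold higher number from compound 2 to compound 3 (0.44 log units; beyond the scatter).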

Compound 3, half-maximal effective concentration: 72 nM
Compound 3: the middle estimate sits 6.3-fold (0.80 log units) above what was measured, and the stated range ends above it.
By their numbers in this assay, from the lowest: compound 3; then compounds 1 and 2 (each within the scatter of the next).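

In this assay, the aromatic carbon para to a large group does not need the double-bonded chain: 3-methoxyphenyl in place of 2-(3-chlorophenyl)ethenyl gives a 2.3-fold lower number from compound 2 to compound 3 (0.36 log units; beyond the scatter), and in place of 2-(2,4,6-trimethylphenyl)ethenyl it gives a 2.1-fold lower number from compound 1 to compound 3 (0.32 log units; beyond the scatter). Both steps are modest, but they go beyond the scatter and point the same way, towards less compound being needed, whereas changing only the ring at the end of the chain produced no step beyond the scatter. No supporting measurement is available to explain this shift.

The step removes the chain and also exchanges the chlorine for a methoxy group, so the compounds shown cannot separate the two changes, and directly attached 3-chlorophenyl would be the matching comparison. Also open, as far as these compounds go, is how the number responds when an amine or a carboxylic acid takes the place of the methoxy group on that ring.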